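A few compounds are considered here, and "the series" means these few. Any claim that something is new, unique, unknown or untested is made for them only; others in the source may bear on it.

Measured so far:
- compound 1 `CCCC[N+](C)(C)CCCC(=O)[O-]` gives > 1000000 nM in an assay for inhibition of gamma-butyrobetaine dioxygenase (Homo sapiens), read by HPLC, with stated times of 15 min and 30 min; on this read-out lower numbers stand for stronger inhibition and higher numbers for weaker inhibition
- compound 2 `C[N+](C)(CCCC(=O)[O-])Cc1ccccc1` gives > 1000000 nM in this assay

Both numbers are limits of this assay and not measured values. For compound 1 the read-out is only a limit, with no number behind it, and compound 1 therefore has no place in an order among the values shown. The same holds for compound 2, whose read-out is a limit as well. Among the compounds with values here, both values sit at the limit of > 1000000 nM in this assay, at which 2 of the 2 values shown sit, so nothing so far shows measurable inhibition.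

The next compound, compound 3 `C[N+](C)(CCCC(=O)[O-])C1CCC1`, is not yet measured. It differs from compound 1 by cyclobutyl in place of butyl on an amine nitrogen. Within the data shown here, no step between measured compounds exists from which the size of such a change could be read; the two known points are limits only.

On that basis no shift beyond the scatter is expected from compound 1 to compound 3 in this assay, and the step of a number no higher from compound 1 to compound 3 (the limit leaves the size open) is an estimate with the limit as its most likely outcome. Compound 3 is expected at 1000000 nM, with a range from 300000 nM to 3000000 nM, most probably again reported as a limit.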

Compound 3, half-maximal inhibitory concentration: 810 nM
Estimate against measurement, compound 3: 1200-fold (3.09 log units) above; measured number below the stated range.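

Within the data shown here, on the amine nitrogen whose other neighbours are three saturated chain carbons, cyclobutyl in place of butyl gives, in this assay, an at least 1200-fold lower number from compound 1 to compound 3 (3.09 log units; beyond the scatter), so this position can carry measurable inhibition, which the earlier compounds did not show. The leaving and entering groups have the same count of heavy atoms, all carbon, and neither has a hydrogen-bond donor or acceptor; what the computed comparison separates is the four-membered ring of cyclobutyl, which butyl lacks. In this assay, compound 3 is the only compound of the three with a number, and the other two read-outs are limits: the limit of > 1000000 nM in this assay, at which 2 of the 3 values shown sit.

On these data alone, it remains open whether the ring itself matters or whether any compact group would do, and how cyclopropyl, cyclopentyl or a branched isobutyl group would read in the same place on the nitrogen. As far as these compounds go, the true size of the step also remains open, as the read-out of compound 1 is a limit, and a single measured number gives no trend across ring sizes.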